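Swapping bromo for methoxy on a histamine H2 ligand

The source may report more compounds than this note shows. Statements on the series, on what has been measured and on what is new or still open speak of the compounds shown alone.

Three compounds with a shared core have been examined in an assay on isolated protein for binding affinity to histamine H2 receptor (Homo sapiens); a lower number here means a stronger inhibitor, a higher number a weaker inhibitor. Compound 1, with structure `O=C(c1ccc(OCCCN2CC[C@H](NS(=O)(=O)c3ccc(Br)cc3)C2)cc1)C1CC1`, gives 290 nM and stands at the lowest number of the three. Compound 3, with structure `CC(=O)c1ccc(OCCCN2CC[C@H](NS(=O)(=O)c3ccc(C#N)cc3)C2)cc1`, gives 2300 nM, a higher number than compound 1 by a margin beyond the usual scatter. Compound 2, with structure `CC(=O)c1ccc(OCCCN2CC[C@H](NC(=O)c3csc(-c4cccnc4)n3)C2)cc1`, gives 6200 nM, the highest number of the set and again beyond the scatter relative to compound 1.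

The next compound, compound 4, has structure `COc1ccc(S(=O)(=O)N[C@H]2CCN(CCCOc3ccc(C(=O)C4CC4)cc3)C2)cc1`. It differs from compound 1 in one place: methoxy in place of bromo on an aromatic carbon. Its place is on an aromatic carbon of a six-membered aromatic ring of carbon only, para to a large group, so the change reads 4-bromophenyl to 4-methoxyphenyl.

No direct comparison of this kind exists among the measured compounds. The only other substituent seen at this position is the nitrile of compound 3, which gives a higher number than compound 1. A modest move in the same direction is expected here, so the step from compound 1 to compound 4 is estimated at a 2.4-fold higher number from compound 1 to compound 4 (0.38 log units; beyond the scatter). Compound 4 is therefore expected to give about 700 nM in this assay, within a range from 250 nM to 2000 nM.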

Compound 4, inhibition constant: 1000 nM
Beside the measured number, compound 4's estimate is 1.4-fold (0.15 log units) below it, and the stated range covers the measured number.
By their numbers in this assay, from the lowest: compound 1; then compound 4; then compound 3; then compound 2.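

Going by these compounds alone, this pair gives the first clean reading of this position. In this assay, replacing bromo with methoxy on the aromatic carbon brings a 3.4-fold higher number from compound 1 to compound 4 (0.54 log units; beyond the scatter) and so counts as a modest step, with everything else in the structure unchanged. Within the data shown here, compound 3, the only earlier compound with another substituent at this place, also differs from compound 1 elsewhere, so the earlier compounds could not show what this position does on its own; nothing measured here bears on the reason for the step.

One pair cannot tell whether the number follows some general trend across groups at this place, and a chloro, a fluoro, a trifluoromethyl or an amine such as dimethylamino would each give a further point for comparison. Also open, as far as these compounds go, is whether the swap from 4-bromophenyl to 4-methoxyphenyl brings a step of similar size when the cyclopropyl carbonyl at the other end of the molecule is replaced by the acetyl group carried by compound 3.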